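Side-chain amine swap on compound 1

A few compounds are considered here, and "the series" means these few. Any claim that something is new, unique, unknown or untested is made for them only; others in the source may bear on it.

Measured compounds:
compound 1 `COc1cc2c(Nc3ccc(C#N)cc3)ncnc2cc1OCCCN1CCCCC1`: 20700 nM
compound 2 `COc1cc2c(Nc3ccc(C#N)cc3)ncnc2cc1OCCCN1CCCCC1CCO`: > 100000 nM
compound 3 `COc1cc2c(Nc3ccc(C#N)cc3)ncnc2cc1OCCCN1CCc2ccccc2C1`: > 100000 nM

In a functional assay on HepG2 cells (Homo sapiens) for antiproliferative activity, read by MTT assay, with a stated time of 72 h (on this read-out lower numbers stand for stronger inhibition and higher numbers for weaker inhibition), compound 1 gives 20700 nM. Compound 2 in this assay gives > 100000 nM, which is a limit of the assay and not a number. Compound 3 in this assay likewise gives > 100000 nM, a limit. Among the measured compounds shown here, compound 1 therefore holds the only number in the set; both other values sit at the limit of > 100000 nM in this assay, at which 2 of the 3 values shown sit.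

Two steps start from compound 1: an at least 4.8-fold higher number from compound 1 to compound 2 (0.68 log units; beyond the scatter) and an at least 4.8-fold higher number from compound 1 to compound 3 (0.68 log units; beyond the scatter). The step from compound 2 to compound 3 is a step that the two limits leave unreadable from compound 2 to compound 3.

Compound 4 `CCN1CCN(CCCOc2cc3ncnc(Nc4ccc(C#N)cc4)c3cc2OC)CC1` differs from compound 1 by 4-ethylpiperazin-1-yl in place of piperidin-1-yl on a saturated chain carbon, three bonds along the chain from an oxygen on an aromatic ring. Neither measured step makes this change; both measured steps that leave compound 1 weakened the compound. The present change keeps the saturated ring size and alters its heteroatom content, a smaller change than either measured one, so a step no larger than the scatter, or a modest weakening, is expected for a 1.4-fold higher number from compound 1 to compound 4 (0.16 log units; within the scatter). Compound 4 is thus estimated at 30000 nM, within 10000 nM to 100000 nM.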

Compound 4, half-maximal inhibitory concentration: 9580 nM
The estimate for compound 4 lay 3.1-fold (0.50 log units) above the measured number; measured number below the stated range.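

In this assay, this position, on a saturated chain carbon, three bonds along the chain from an oxygen on an aromatic ring, now shows a change that lowers the number: 4-ethylpiperazin-1-yl in place of piperidin-1-yl gives a 2.2-fold lower number from compound 1 to compound 4 (0.33 log units; beyond the scatter), whereas both earlier steps from compound 1 raised it. Against the other two side-chain amines, the same group gives an at least 10-fold lower number from compound 3 to compound 4 (1.01 log units; beyond the scatter) and an at least 10-fold lower number from compound 2 to compound 4 (1.01 log units; beyond the scatter). Compound 2 and compound 3 each stand at a limit of the assay and not at a number: the limit of > 100000 nM in this assay, at which 2 of the 4 values shown sit.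

The compounds shown do not separate the contribution of the added ring nitrogen from that of the ethyl group; piperazin-1-yl and morpholin-4-yl are absent from the set. The step between the two limits cannot be read.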